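Chain lengthening on an ester tail and cytotoxicity

A few compounds are considered here, and "the series" means these few. Any claim that something is new, unique, unknown or untested is made for them only; others in the source may bear on it.

Measured compounds:
compound 1 `CCOC(=O)CCC(=O)N1CCN(CCCOc2cc3c(Nc4ccc(F)c(Cl)c4)ncnc3cc2OC)CC1`, 35.6%
compound 2 `CCCOC(=O)CCC(=O)N1CCN(CCCOc2cc3c(Nc4ccc(F)c(Cl)c4)ncnc3cc2OC)CC1`, 23.4%
compound 3 `CCCCCOC(=O)CCC(=O)N1CCN(CCCOc2cc3c(Nc4ccc(F)c(Cl)c4)ncnc3cc2OC)CC1`, 18.2%

In a functional assay on A549 cells (Homo sapiens) for cytotoxicity, read by MTT assay, with a stated time of 24 h, tested at 80 uM (a lower number here means a stronger effect, a higher number a weaker effect of the compound at the concentration tested), compound 1 gives 35.6%. The change methyl in place of hydrogen on a saturated chain carbon, two bonds along the chain from an oxygen next to a carbonyl group made a step of a number 12.2 percentage points lower from compound 1 to compound 2 (beyond the scatter). Going further, propyl in place of hydrogen on a saturated chain carbon, two bonds along the chain from an oxygen next to a carbonyl group gave a number 17.4 percentage points lower from compound 1 to compound 3 (beyond the scatter), while between compound 2 and compound 3 the step is a number 5.2 percentage points lower from compound 2 to compound 3 (within the scatter).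

Compound 4 `CCCCCCOC(=O)CCC(=O)N1CCN(CCCOc2cc3c(Nc4ccc(F)c(Cl)c4)ncnc3cc2OC)CC1` is not yet measured. It differs from compound 3 by methyl in place of hydrogen on a saturated chain carbon, five bonds along the chain from an oxygen next to a carbonyl group, the same kind of change as from compound 1 to compound 2, though the place differs: five bonds along the chain from the oxygen rather than two. The cores of compound 1 and compound 3 differ by propyl in place of hydrogen on a saturated chain carbon, two bonds along the chain from an oxygen next to a carbonyl group only in the chain.

Because the step of a number 12.2 percentage points lower from compound 1 to compound 2 (beyond the scatter) was modest and the step of a number 5.2 percentage points lower from compound 2 to compound 3 (within the scatter) lay within the scatter, compound 4 is expected to show a number 3.2 percentage points lower from compound 3 to compound 4 (within the scatter) in this assay. Compound 4 is estimated at 15%, between 6% and 27%.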

Compound 4, a percentage reported as activity, at one concentration (the size of the read-out at that concentration, not a potency): 42.9%
Compound 4: the middle estimate sits 27.9 percentage points below what was measured; measured number outside the range, above it.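

In this assay, adding a methyl to the ester chain did not carry over from one core to the other, and a number 24.7 percentage points higher from compound 3 to compound 4 (beyond the scatter) runs against the earlier step: the same change on two cores in this assay, a number 12.2 percentage points lower (beyond the scatter) from compound 1 to compound 2 and a number 24.7 percentage points higher (beyond the scatter) from compound 3 to compound 4, 36.9 percentage points apart, beyond the scatter of two such steps.
The longer chain extension likewise reversed, with a number 19.5 percentage points higher from compound 2 to compound 4 (beyond the scatter) set against its counterpart: the same change on two cores in this assay, a number 17.4 percentage points lower (beyond the scatter) from compound 1 to compound 3 and a number 19.5 percentage points higher (beyond the scatter) from compound 2 to compound 4, 36.9 percentage points apart, beyond the scatter of two such steps.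
With a number 7.3 percentage points higher from compound 1 to compound 4 (within the scatter), compound 4 breaks the downward run from compound 1 through compound 3, which shows that the direction of a step depends on the chain it is made on but does not show why.

The compounds shown leave open where between compound 3 and compound 4 the turn lies, and a butyl ester sits outside the pentyl-to-hexyl pair. From the compounds shown here alone, whether a longer chain or a carboxylic acid in place of the ester would follow compound 3 or compound 4 in this assay also stays open.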